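Adding Ring Nitrogen to the Aryl Group on Piperazine

The source may report more compounds than this note shows. Statements on the series, on what has been measured and on what is new or still open speak of the compounds shown alone.

Compound 1 `O=C(CN1CCN(c2ccccc2)CC1)Nc1nc2ccccc2[nH]1` and compound 2 `O=C(CN1CCN(c2ccccn2)CC1)Nc1nc2ccccc2[nH]1` share a core and differ only in the ring attached to the amine nitrogen in the ring. In a functional assay, read by spectrophotometry, with a stated time of 30 min, tested at 25 ug/mL (a lower number here means a weaker effect, a higher number a stronger effect of the compound at the concentration tested), compound 1 gives 11.5%, and compound 2 gives 40.9%. Going by the values given here, the step of a number 29.4 percentage points higher from compound 1 to compound 2 (beyond the scatter) lies beyond the scatter, so compound 2 holds the higher of the two numbers known so far. Compound 3 `O=C(CN1CCN(c2ncccn2)CC1)Nc1nc2ccccc2[nH]1` is not yet measured; it differs from compound 2 by pyrimidin-2-yl in place of pyridin-2-yl on an amine nitrogen in a ring. Among the compounds with values here, only the step from compound 1 to compound 2 bears on this change: it also swapped one six-membered aromatic ring for another on the same amine nitrogen, and the read-out rose. A single step is a thin basis, so a smaller rise, or none beyond the scatter, is expected here. For compound 3 the expected value is 50%, with a range from 30% to 70%. This corresponds to an estimated step of a number 9.1 percentage points higher from compound 2 to compound 3 (within the scatter).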

Compound 3, a percentage reported as activity, at one concentration (the size of the read-out at that concentration, not a potency) in the functional assay: 20.4%
Compound 3: middle estimate off by 29.6 percentage points, on the high side; measured number below the stated range.
By their numbers in the functional assay, from the lowest: compounds 1 and 3 (each within the scatter of the next); then compound 2.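

At this place on the amine nitrogen in a ring, the read-out in the functional assay does not simply follow the number of nitrogens in the aromatic ring: pyrimidin-2-yl in place of pyridin-2-yl gives a number 20.5 percentage points lower from compound 2 to compound 3 (beyond the scatter). Compared with phenyl, pyrimidin-2-yl gives a number 8.9 percentage points higher from compound 1 to compound 3 (within the scatter), so compound 1 and compound 3 cannot be told apart, and the gain seen with pyridin-2-yl is specific to that ring among these three. In a physicochemical assay for lipophilicity, read by spectrophotometry, using the shake flask method, measured as octanol-water partition, with a stated time of 24 h (a lower number here means a more polar compound, a higher number a more lipophilic compound), compound 2 gives 1.05 and compound 3 gives 1.85. The change from pyridin-2-yl to pyrimidin-2-yl also shifts the result in the physicochemical assay: the measured partition coefficient of compound 2, 1.05, and of compound 3, 1.85, a number 0.80 log units higher (beyond the scatter)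

One pair cannot show whether this shift is tied to the fall in the functional assay. As far as these compounds go, it also remains open how a non-aromatic group on this nitrogen, such as a cyclohexyl ring or an acetyl group, would compare.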